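The compounds below may be only part of what the source reports. "The series", "measured", "known", "first", "only" and "open" are said of these compounds alone.

Working notes on the series. Compound 1 `COc1cccc(/C=C/C(=O)c2ccc[nH]2)c1` gives 6200 nM in an assay for inhibition of cytochrome P450 1A1 (Homo sapiens), read by fluorescence, using microsomes, with a stated time of 10 min; on this read-out higher numbers stand for weaker inhibition and lower numbers for stronger inhibition. Compound 2 `COc1cc(/C=C/C(=O)c2ccc[nH]2)cc(OC)c1` gives 6100 nM in this assay. The step of a 1.0-fold lower number from compound 1 to compound 2 (0.01 log units; within the scatter) lies within the scatter, so compound 2 and compound 1 cannot be told apart on these two numbers; compound 2 is simply the compound from which the next step is taken, and its number is the nearer of the two for this purpose.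

Compound 3 `COc1cc(/C=C/C(=O)c2ccc[nH]2)cc(OC)c1OC` is the next member, not yet measured in this assay. It differs from compound 2 by methoxy in place of hydrogen on an aromatic carbon. Within the data shown here, the one measured step that bears on this change is the earlier addition of a methoxy group to the same six-membered ring, a 1.0-fold lower number from compound 1 to compound 2 (0.01 log units; within the scatter), which lay within the scatter. A third methoxy group on that ring is therefore expected to move the number no further than the scatter allows, in no particular direction, so the expected step is a 1.0-fold lower number from compound 2 to compound 3 (0.01 log units; within the scatter). On that basis compound 3 is estimated at 6000 nM, with a range from 3000 nM to 12000 nM, pending measurement.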

Compound 3, half-maximal inhibitory concentration: > 20000 nM
Compound 3: a limit, no number; the forecaster's own chance of this, stated with the estimate: 5%; at least 3.3-fold (0.52 log units) between middle value and limit.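

The same replacement, methoxy in place of hydrogen on an aromatic carbon, does not read the same at every carbon of this ring: the earlier case gave a 1.0-fold lower number from compound 1 to compound 2 (0.01 log units; within the scatter), whereas the carbon ortho to two methoxy groups and para to a group of 9 heavy atoms gives an at least 3.2-fold higher number from compound 2 to compound 3 (0.51 log units; beyond the scatter). Among these compounds, this is the first step that lies beyond the scatter, and it runs towards weaker inhibition, so this position is sensitive to the change in a way that compound 1 and compound 2 could not show. In this assay compound 3 gives a limit and not a number, so the step has a lower bound but no measured size: the limit of > 20000 nM in this assay, at which 1 of the 3 values shown sits.

The compounds shown hold only hydrogen or methoxy at this carbon, so it remains open whether a hydroxyl group, a fluorine atom or a longer ethoxy chain there would give the same result. Also open is whether a methoxy group at this carbon would have the same effect without the two methoxy groups ortho to it, as the compounds shown do not separate these cases.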